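Anilino for ((trifluoromethyl)sulfonyl)oxy on the aromatic ring

This account rests on a few compounds, and the source may have more. Where it says the series, first, only, none or still open, it means among the compounds named here.

In a functional assay on NALM-6 cells (Homo sapiens) for cytotoxicity, with a stated time of 72 h (on this read-out higher numbers stand for an effect only at larger amounts of compound and lower numbers for an effect already at smaller amounts), compound 1 (`C=C[C@@](C)(/C=C/c1ccc(OCc2ccccc2)cc1)CCC=C(C)C`) gives > 43400 nM, which is a limit of the assay and not a number. In this assay compound 2 (`C=C[C@@](C)(/C=C/c1ccc(OS(=O)(=O)C(F)(F)F)cc1)CCC=C(C)C`) gives > 43400 nM, which is likewise only a limit. Compound 3 (`C=C[C@@](C)(/C=C/c1ccc(Nc2ccccc2)cc1)CCC=C(C)C`) carries anilino in place of ((trifluoromethyl)sulfonyl)oxy on an aromatic carbon. Within the data shown here, the one measured step bearing on this change is a step that the two limits leave unreadable from compound 1 to compound 2, with (trifluoromethyl)sulfonyl in place of benzyl on an oxygen on an aromatic ring. That step offers no size to carry over. Among the measured compounds shown here, with the series so far at the limit of > 43400 nM in this assay, at which 2 of the 2 values shown sit, no firm direction can be set, and compound 3 is expected to stay close to that limit. The expected step is an at least 1.0-fold lower number from compound 2 to compound 3 (0.03 log units; that floor lies within the scatter). For compound 3 the estimate is 40000 nM, with an expected range from 15000 nM to 80000 nM.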

Compound 3, half-maximal effective concentration: > 43400 nM
Compound 3: no number, only a limit; the forecaster's own chance of this, stated with the estimate: 65%; middle value at least 1.0-fold (0.03 log units) away from the limit.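

No step among compound 1, compound 2 and compound 3 can be read, as each value is only a limit of the assay: the limit of > 43400 nM in this assay, at which 3 of the 3 values shown sit.

The compounds shown leave open whether benzyloxy, ((trifluoromethyl)sulfonyl)oxy and anilino differ at all in this assay, and whether any group on this aromatic carbon gives a readable number.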